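A few compounds are considered here, and "the series" means these few. Any claim that something is new, unique, unknown or untested is made for them only; others in the source may bear on it.

Series notes. Compound 1 `Cc1ccc(C2=NN(c3ccc([N+](=O)[O-])cc3)C(c3cn(-c4ccccc4)nc3-c3ccc(Cl)c(Cl)c3)C2)cc1` is measured in a functional assay on the whole organism (strain Wistar) for inhibition, with Rattus norvegicus as the target, read by paw edema, with stated times of 30 min and 60 min, at a dose of 50 mg/kg by the oral route (a lower number here means less inhibition, a higher number more inhibition at the dose given (going by the name of the read-out)), and gives 72.5%. Compound 2 `CCC(=O)N1N=C(c2ccc(C)cc2)CC1c1cn(-c2ccccc2)nc1-c1ccc(Cl)c(Cl)c1` gives 61.1% in this assay; its difference from compound 1 is propanoyl in place of 4-nitrophenyl on an amine nitrogen in a ring, and this made a step of a number 11.4 percentage points lower from compound 1 to compound 2 (beyond the scatter). Compound 3 `O=[N+]([O-])c1ccc(N2N=C(c3ccc(Cl)cc3)CC2c2cn(-c3ccccc3)nc2-c2ccc(Cl)c(Cl)c2)cc1` gives 57.3% in this assay; the two cores differ by chloro in place of methyl on an aromatic carbon, which made the step of a number 15.2 percentage points lower from compound 1 to compound 3 (beyond the scatter). Compound 4 `CCC(=O)N1N=C(c2ccc(Cl)cc2)CC1c1cn(-c2ccccc2)nc1-c1ccc(Cl)c(Cl)c1` is not yet measured. Its difference from compound 3 is propanoyl in place of 4-nitrophenyl on an amine nitrogen in a ring, the same kind of change as that from compound 1 to compound 2; around the place, the ring atom two ring bonds away bears a 4-chlorophenyl group rather than a 4-methylphenyl group. The step expected here is a number 11.3 percentage points lower from compound 3 to compound 4 (beyond the scatter), resting on the step of a number 11.4 percentage points lower from compound 1 to compound 2 (beyond the scatter) made by the same kind of change. For compound 4 the expected value is 46%, with a range from 34% to 58%.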

Compound 4, a percentage reported as inhibition, in the whole organism at one dose (the size of the read-out at that dose, not a potency): 61.1%
The estimate for compound 4 lay 15.1 percentage points below the measured number; the whole stated range lies below it.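

In this assay, the step for propanoyl in place of 4-nitrophenyl does not carry from one core to the other: the same change on two cores in this assay, a number 11.4 percentage points lower (beyond the scatter) from compound 1 to compound 2 and a number 3.8 percentage points higher (within the scatter) from compound 3 to compound 4, 15.2 percentage points apart, beyond the scatter of two such steps The step for chloro in place of methyl likewise depends on the group on the ring nitrogen: the same change on two cores in this assay, a number 15.2 percentage points lower (beyond the scatter) from compound 1 to compound 3 and no change at the digits printed (within the scatter) from compound 2 to compound 4, 15.2 percentage points apart, beyond the scatter of two such steps With the new steps, a number 3.8 percentage points higher from compound 3 to compound 4 (within the scatter) and no change at the digits printed from compound 2 to compound 4 (within the scatter), the two changes are not additive across these four compounds, though the compounds do not show why, and a single square at one dose cannot show how general this is.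

Open, on these data alone, is whether a longer acyl chain such as butanoyl, or an acetyl group, behaves like propanoyl on the ring nitrogen. Also open, as far as these compounds go, is whether methoxy or fluoro in place of methyl follows chloro on each core.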